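Notes on compound 3 and the untested compound 4

A few compounds are considered here, and "the series" means these few. Any claim that something is new, unique, unknown or untested is made for them only; others in the source may bear on it.

Compound 1 `CC1=CC[C@H](C(C)(C)N=C=S)CC1` in a functional assay on UACC-62 cells (Homo sapiens) for inhibition, read by sulforhodamine B assay, with a stated time of 48 h; on this read-out higher numbers stand for weaker inhibition of growth and lower numbers for stronger inhibition of growth: "not determined" (no result reported)
Compound 2 `CC1=CC[C@H](C(C)(C)NC(=S)NN)CC1` in this assay: "not determined" (no result reported)
Compound 3 `CC1=CC[C@H](C(C)(C)NC(=S)N/N=C/c2ccccc2O)CC1` in this assay: 10800 nM

Among the measured compounds shown here, compound 3 is the only member of the set with a number in this assay; compound 1 and compound 2 carry no result there. For the measured compounds named here, no pair of measured compounds differs in one place, so no step is known from which the effect of a change at the imine carbon could be read. Whether a swap of the aryl group moves the read-out at all is therefore open.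

Compound 4 `CC1=CC[C@H](C(C)(C)NC(=S)N/N=C/c2ccc(Cl)cc2)CC1` differs from compound 3 in one place: 4-chlorophenyl in place of 2-hydroxyphenyl on a carbon with a double bond to nitrogen. With nothing in the set to anchor the direction, the working assumption is that the step from compound 3 to compound 4 stays within the usual scatter, and the expected step is a 1.1-fold higher number from compound 3 to compound 4 (0.05 log units; within the scatter). On that basis compound 4 is estimated at about 12000 nM in this assay, with a range from 4000 nM to 36000 nM. The range is kept wide, since a single value for compound 3 gives no sense of how this position behaves.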

Compound 4, concentration for total growth inhibition: > 100000 nM
Compound 4 was reported as a limit; the forecaster's own chance of this, stated with the estimate: 10%; at least 8.3-fold (0.92 log units) between middle value and limit.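

The carbon with a double bond to nitrogen is not a silent position: in this assay, 4-chlorophenyl in place of 2-hydroxyphenyl gives an at least 9.2-fold higher number from compound 3 to compound 4 (0.96 log units; beyond the scatter). So the aryl group here does move the read-out, a point that compound 3 alone could not settle. The size of the step is fixed from one side only, since compound 4 carries a limit of the assay and not a number: the limit of > 100000 nM in this assay, at which 1 of the 4 values shown sits.

Going by these compounds, what a plain phenyl group or a 2-methoxyphenyl group on this carbon would give stays open, so the step cannot yet be divided between the departure of 2-hydroxyphenyl and the arrival of 4-chlorophenyl. Steps to compound 1 and compound 2 cannot be read, and the role of the shared core remains open.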